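The source may hold more compounds than are shown below. What is called first, only, known or untested is meant among the compounds shown, and "the series" means these compounds.

Measured so far:
Compound 1, `Cc1ccc(-c2nc3ccccc3s2)cc1NC(=O)c1cc([N+](=O)[O-])c(N2CCCCC2)cc1Cl`, in an ADME assay for permeability, using PAMPA, at pH 7.4 (a lower number here means that the compound crosses the layer more slowly, a higher number that the compound crosses the layer faster), gives < 1 10^-6 cm/s, which is a limit of the assay and not a number.
Compound 2, `O=C(Nc1cc(-c2nc3ccccc3o2)ccc1F)c1cc([N+](=O)[O-])ccc1Cl`, in this assay gives 214 10^-6 cm/s.
Compound 3, `O=C(Nc1cc(-c2nc3ccccc3s2)ccc1F)c1cc([N+](=O)[O-])ccc1Cl`, in this assay gives 191 10^-6 cm/s.

Of the numbers in hand, compound 2 and compound 3 sit within the scatter of each other: a 1.1-fold lower number from compound 2 to compound 3 (0.05 log units; within the scatter). Going by the values given here, the only other value shown, that of compound 1, is a limit, so compound 2 cannot be placed against it.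

Compound 4, `COc1ccc(-c2nc3ccccc3o2)cc1NC(=O)c1cc([N+](=O)[O-])ccc1Cl`, differs from compound 2 in one place: methoxy in place of fluoro on an aromatic carbon. Among the compounds with values here, none of the measured pairs touches this position or these groups; the one step known, the change of ring system in a 1.1-fold lower number from compound 2 to compound 3 (0.05 log units; within the scatter), concerns a different part of the molecule and does not bear on an exchange of fluoro for methoxy. With nothing in the data pointing to a direction, compound 4 is expected to stay close to compound 2, and a 1.3-fold lower number from compound 2 to compound 4 (0.10 log units; within the scatter) is the step the estimate implies, within the scatter. Compound 4 is therefore estimated at 170 10^-6 cm/s in this assay, between 80 10^-6 cm/s and 350 10^-6 cm/s.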

Compound 4, apparent permeability: 274 10^-6 cm/s
Beside the measured number, compound 4's estimate is 1.6-fold (0.21 log units) below it; low and high end bracket the measured number.
By their numbers in this assay, from the lowest: compounds 3, 2 and 4 (each within the scatter of the next). At a limit, below all of these: compound 1.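

At this position, ortho to a large group and para to a 1,3-benzoxazol-2-yl group, the exchange of fluoro for methoxy gives a 1.3-fold higher number from compound 2 to compound 4 (0.11 log units; within the scatter) in this assay. Going by these compounds alone, this is the first reading of any change at this place, since the only earlier step concerned the ring system, and it shows that methoxy, which brings a hydrogen-bond acceptor that fluoro does not, leaves the number within the scatter. Nothing at hand bears on why the exchange reads this way.

Going by these compounds, whether an amine, a carboxylic acid or a longer chain at this position would also stay within the scatter remains open. So does whether methoxy reads the same when the 1,3-benzoxazol-2-yl group is replaced by the 1,3-benzothiazol-2-yl group of compound 3.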